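Compound 3: a 3-bromophenyl replaces 4-fluorophenyl

A few compounds are considered here, and "the series" means these few. Any claim that something is new, unique, unknown or untested is made for them only; others in the source may bear on it.

Compound 1 `COc1cc(-c2cccc3nc(-c4cccc(F)c4)oc23)cc(OC)c1OC`: 3300 nM
Compound 2 `COc1cc(-c2cccc3nc(-c4ccc(F)cc4)oc23)cc(OC)c1OC`: 8700 nM

Both values come from a functional assay on NCI-H460 cells (Homo sapiens) for antiproliferative activity, read by MTT assay, with a stated time of 48 h; on this read-out higher numbers stand for weaker inhibition and lower numbers for stronger inhibition. Of the two numbers, compound 2 has the higher, at 8700 nM, which marks it as the weaker inhibitor of the pair. Compound 3 `COc1cc(-c2cccc3nc(-c4cccc(Br)c4)oc23)cc(OC)c1OC` has not yet been measured. It differs from compound 2 by having 3-bromophenyl in place of 4-fluorophenyl on an aromatic carbon.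

Going by the values given here, the only measured step that bears on this change is a 2.6-fold higher number from compound 1 to compound 2 (0.42 log units; beyond the scatter), a modest one. It shows that 3-fluorophenyl gave the lower number of the pair, and compound 3 also carries its halogen on a 3-substituted phenyl. Among the compounds with values here, no measured pair compares bromine with fluorine, so that part of the change remains open. A modest shift toward stronger inhibition is therefore expected in this assay, similar in size to the measured step, and the expected change is a 2.5-fold lower number from compound 2 to compound 3 (0.40 log units; beyond the scatter). For compound 3 the estimated value is 3500 nM, with an expected range from 1200 nM to 9500 nM.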

Compound 3, half-maximal inhibitory concentration: 3800 nM
Beside the measured number, compound 3's estimate is 1.1-fold (0.04 log units) below it, within the range that was stated.
By their numbers in this assay, from the lowest: compounds 1 and 3 (each within the scatter of the next); then compound 2.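

In this assay, the earlier pair showed only that moving fluorine changed the number, whereas compound 3 adds a second halogen and so separates the identity of the halogen from the form of the ring. Bromo in place of fluoro on the aromatic carbon gives a 1.2-fold higher number from compound 1 to compound 3 (0.06 log units; within the scatter), so 3-bromophenyl and 3-fluorophenyl cannot be told apart here, while 3-bromophenyl in place of 4-fluorophenyl gives a 2.3-fold lower number from compound 2 to compound 3 (0.36 log units; beyond the scatter), and among these three compounds the 4-fluorophenyl group alone stands apart with the higher number. No supporting evidence is available to explain these differences.

The compounds shown leave open whether the higher number of compound 2 goes with the 4-fluorophenyl group in particular or with any 4-substituted phenyl, as a 4-bromophenyl group would help to show. They also leave open whether the match between the two halogens extends beyond them, for instance to a chlorine, a methoxy group, an amine or a carboxylic acid on the same phenyl ring.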